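Removing the Trifluoromethyl Group from Compound 2

The source may report more compounds than this note shows. Statements on the series, on what has been measured and on what is new or still open speak of the compounds shown alone.

Compound 1, `Cc1ccc(-c2nnc(-c3ccc(CN4CCN(C)CC4)cc3)o2)cc1Nc1nccc(-c2cccnc2)n1`, in a functional assay on HL-60 cells (Homo sapiens) for inhibition, read by MTT assay, with a stated time of 72 h (on this read-out lower numbers stand for stronger inhibition and higher numbers for weaker inhibition), gives 570 nM.
Compound 2, `Cc1ccc(-c2nnc(-c3ccc(CN4CCN(CCN=C=S)CC4)c(C(F)(F)F)c3)o2)cc1Nc1nccc(-c2cccnc2)n1`, in this assay gives 70 nM.

Compound 2 stands lowest of the two measured values in this assay, and compound 1 gives a higher number, beyond the usual scatter. Compound 3, `Cc1ccc(-c2nnc(-c3ccc(CN4CCN(CCN=C=S)CC4)cc3)o2)cc1Nc1nccc(-c2cccnc2)n1`, differs from compound 2 by hydrogen in place of trifluoromethyl on an aromatic carbon. Within the data shown here, no single-change step is available to anchor this change, so the expected step is modest and upward. Compound 3 is estimated at 150 nM (range 50 nM to 500 nM), a step of a 2.1-fold higher number from compound 2 to compound 3 (0.33 log units; beyond the scatter) that is expected to lie near the edge of the scatter.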

Compound 3, half-maximal inhibitory concentration: 290 nM
Compound 3: the middle estimate sits 1.9-fold (0.29 log units) below what was measured; low and high end bracket the measured number.
By their numbers in this assay, from the lowest: compound 2; then compounds 3 and 1 (each within the scatter of the next).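

In this assay, among these compounds, the trifluoromethyl group on this aromatic carbon makes a measurable difference: hydrogen in its place gives a 4.1-fold higher number from compound 2 to compound 3 (0.62 log units; beyond the scatter), the first single-change reading at this position. The other single change, the isothiocyanate chain in place of a hydrogen atom on the saturated chain carbon, gives a 2.0-fold lower number from compound 1 to compound 3 (0.29 log units; within the scatter), which stays within the scatter when hydrogen sits on the aromatic carbon. No evidence at hand explains either step.

On these data alone, whether a methyl, a chlorine or a nitrile on that aromatic carbon would match trifluoromethyl remains open. So does whether an amine or a longer chain in place of the isothiocyanate would change the number.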